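Pyrimidin-4-yl in Place of Cyclopropyl: Cytotoxicity Outlook

A few compounds are considered here, and "the series" means these few. Any claim that something is new, unique, unknown or untested is made for them only; others in the source may bear on it.

Compound 1, `N#CCCCn1c(Cn2c(=O)n(-c3ncccn3)c3ccncc32)cc2cc(Cl)ccc21`: > 50000 nM
Compound 2, `N#CCCCn1c(Cn2c(=O)n(C3CC3)c3ccncc32)cc2cc(Cl)ccc21`: > 50000 nM

In an ADME assay on HeLa cells (Homo sapiens) for cytotoxicity, read by ATP content, with a stated time of 3 days (on this read-out lower numbers stand for higher toxicity in this test and higher numbers for lower toxicity in this test), compound 1 reaches only a limit of the test, > 50000 nM. Compound 2 likewise shows only a limit, > 50000 nM. Both values sit at the limit of > 50000 nM in this assay, at which 2 of the 2 values shown sit, so the step that the two limits leave unreadable from compound 1 to compound 2 has no readable size. Compound 3, `N#CCCCn1c(Cn2c(=O)n(-c3ccncn3)c3ccncc32)cc2cc(Cl)ccc21`, is not yet measured; it carries pyrimidin-4-yl in place of cyclopropyl on an aromatic nitrogen. Among the compounds with values here, the one measured step bears on this change but gives no size or direction, so nothing beyond scatter is expected. For compound 3 the value is estimated at 60000 nM, ranging from 25000 nM to 150000 nM, an expected step that the limit leaves unreadable from compound 2 to compound 3.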

Compound 3, half-maximal cytotoxic concentration: > 50000 nM
Compound 3: a limit, no number; the forecaster's own chance of this, stated with the estimate: 80%; the middle value does not contradict the limit.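

Within the data shown here, compound 1, compound 2 and compound 3 all stop at a limit of the test, so no step among them can be read: the limit of > 50000 nM in this assay, at which 3 of the 3 values shown sit.

Left open in this assay is whether any group on this aromatic nitrogen gives a readable number.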